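The source may hold more compounds than are shown below. What is called first, only, known or untested is meant among the compounds shown, and "the series" means these compounds.

Measured so far:

Compound 1 `O=C1/C(=C/c2ccc(Cl)cc2)CCC/C1=C\c1ccccc1[N+](=O)[O-]` gives > 400000 nM in the cytotoxicity test.
Compound 2 `CN(C)c1ccc(/C=C2\CCC/C(=C\c3ccccc3[N+](=O)[O-])C2=O)cc1` gives > 400000 nM.
Compound 3 `O=C1/C(=C/c2ccc(Cl)cc2)CCC/C1=C\c1ccc([N+](=O)[O-])cc1` gives 332000 nM.

All three compounds were tested in an ADME assay on HPLF cells (Homo sapiens) for cytotoxicity, with a stated time of 24 h; on this read-out higher numbers stand for lower toxicity in this test and lower numbers for higher toxicity in this test. The value of compound 1 is a limit of the assay, not a number. The value of compound 2 is likewise a limit. Only compound 3 yields an actual number, 332000 nM.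

Compound 1 and compound 2 differ by one change, (dimethylamino in place of chloro on an aromatic carbon). Because both sit at the limit of > 400000 nM in this assay, at which 2 of the 3 values shown sit, the step that the two limits leave unreadable from compound 1 to compound 2 cannot be read. Compound 1 and compound 3 share the same atoms joined differently; the difference between the two cores is not broken down here.

Compound 4 `CN(C)c1ccc(/C=C2\CCC/C(=C\c3ccc([N+](=O)[O-])cc3)C2=O)cc1` is not yet measured. It differs from compound 3 by dimethylamino in place of chloro on an aromatic carbon, and the place of the change is described in the same words as for the step from compound 1 to compound 2, so it is the same change made on the core of compound 3.

The step from compound 3 to compound 4 is estimated as a 1.1-fold higher number from compound 3 to compound 4 (0.06 log units; within the scatter), a small one, resting on the fact that compound 3 gives 332000 nM and that the earlier pair shows no readable shift. Compound 4 is therefore expected to land near 380000 nM, somewhere between 200000 nM and 800000 nM, and it may well come back as a limit again.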

Compound 4, half-maximal cytotoxic concentration: > 400000 nM
Compound 4 gave a limit, no number (the forecaster's own chance of this, stated with the estimate: 50%); middle value at least 1.0-fold (0.02 log units) from the limit.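

Compound 4 gives > 400000 nM in this assay and this is a limit of the assay, not a number. On the core of compound 3, dimethylamino in place of chloro on an aromatic carbon therefore reads as an at least 1.2-fold higher number from compound 3 to compound 4 (0.08 log units; that floor lies within the scatter) so the result shows no lower number after the change on this core, but it gives only a floor and leaves the true size of the step unknown. It does not show that the change has the same size on the core of compound 1, since neither that step nor the step from compound 2 to compound 4 can be read, because each of these pairs rests on two limits: the limit of > 400000 nM in this assay, at which 3 of the 4 values shown sit.

The compounds shown leave open how other groups on the same aromatic carbon would read in this assay, for example a methoxy group, a primary amine or a carboxylic acid in place of chloro or dimethylamino. They also leave open whether a nitrile or a trifluoromethyl group in place of the nitro group would give an actual number on either core, which would allow a change to be compared from one core to another.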